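Hydroxy for nitro on a bis-pyridyl hydrazone

This account rests on a few compounds, and the source may have more. Where it says the series, first, only, none or still open, it means among the compounds named here.

Compound 1, `O=C(NN=C(c1ccccn1)c1ccccn1)c1cccs1`, gives 950 nM in an ADME assay on cells (Homo sapiens) for antiproliferative activity, read by MTT assay; a higher number here means a weaker inhibitor, a lower number a stronger inhibitor. Compound 2, `O=C(NN=C(c1ccccn1)c1ccccn1)c1ccncc1`, gives 830 nM. Compound 3, `O=C(NN=C(c1ccccn1)c1ccccn1)c1ccc([N+](=O)[O-])cc1`, gives 260 nM.

Compound 3 gives the lowest number of the three; compound 1 and compound 2 both give higher numbers, beyond the scatter, so compound 3 is the strongest inhibitor measured so far. Compound 4, `O=C(NN=C(c1ccccn1)c1ccccn1)c1ccc(O)cc1`, differs from compound 3 in one place: hydroxy in place of nitro on an aromatic carbon. For the measured compounds named here, the only measured step, a 1.1-fold lower number from compound 1 to compound 2 (0.06 log units; within the scatter), swaps the group on the carbonyl carbon and lies within the scatter; no measured step changes a substituent on this ring, so nothing measured bears directly on the swap. Compound 4 is therefore expected to give a higher number, a 2.3-fold higher number from compound 3 to compound 4 (0.36 log units; beyond the scatter), with wide uncertainty. The estimate for compound 4 is 600 nM, between 250 nM and 1500 nM.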

Compound 4, half-maximal inhibitory concentration: 7530 nM
The estimate for compound 4 lay 13-fold (1.10 log units) below the measured number; measured number above the stated range.
By their numbers in this assay, from the lowest: compound 3; then compounds 2 and 1 (each within the scatter of the next); then compound 4.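

In this assay, for the compounds shown here, the group on this aromatic carbon, para to a large group, matters greatly: hydroxy for nitro gives a 29-fold higher number from compound 3 to compound 4 (1.46 log units; beyond the scatter) as the first measured substituent change on this ring. The 4-hydroxyphenyl group also compares poorly with the other carbonyl partners, giving a 9.1-fold higher number from compound 2 to compound 4 (0.96 log units; beyond the scatter) and a 7.9-fold higher number from compound 1 to compound 4 (0.90 log units; beyond the scatter) in the same assay. No measurement here explains the size of this loss.

As far as these compounds go, whether the loss follows from gaining hydroxy or from losing nitro stays open. An amine or a methoxy group on this same carbon would help separate the two.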